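Opening the ring: from compound 3 to compound 4

The source may report more compounds than this note shows. Statements on the series, on what has been measured and on what is new or still open speak of the compounds shown alone.

Of the compounds shown here, three sharing one core have been tested in a functional assay on the whole organism with Mus musculus as the target, in the rotarod test; on this read-out lower numbers stand for an effect already at smaller amounts and higher numbers for an effect only at larger amounts of compound. Compound 1 `CN(C)CC(=O)NCC(=O)N(C)c1ccc(Cl)cc1C(=O)c1ccccc1Cl` gives 26 mg/kg in this assay. Compound 2 `CCCC(=O)NCC(=O)N(C)c1ccc(Cl)cc1C(=O)c1ccccc1Cl` gives 55.2 mg/kg. Compound 3 `CN(C(=O)CNC(=O)CN1CCCCC1)c1ccc(Cl)cc1C(=O)c1ccccc1Cl` gives > 100 mg/kg, which is a limit of the assay rather than a number. Among the measured values it sits at the limit of > 100 mg/kg in this assay, at which 1 of the 3 values shown sits. The step from compound 1 to compound 2 is a 2.1-fold higher number from compound 1 to compound 2 (0.33 log units; beyond the scatter). The step from compound 1 to compound 3 is an at least 3.8-fold higher number from compound 1 to compound 3 (0.58 log units; beyond the scatter), and that from compound 2 to compound 3 is an at least 1.8-fold higher number from compound 2 to compound 3 (0.25 log units; that floor lies within the scatter).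

Compound 4 `CCN(CC)CC(=O)NCC(=O)N(C)c1ccc(Cl)cc1C(=O)c1ccccc1Cl` has not yet been measured. It differs from compound 3 by diethylamino in place of piperidin-1-yl on a saturated chain carbon bound to a carbonyl carbon. The step that bears most on this change, an at least 3.8-fold higher number from compound 1 to compound 3 (0.58 log units; beyond the scatter), pushed the number up when a piperidin-1-yl ring replaced dimethylamino; compound 4 carries an amine with no ring again, so the number is expected to come back down. Compound 4 is therefore expected to give 55 mg/kg, with a range from 25 mg/kg to 150 mg/kg. The expected step is an at least 1.8-fold lower number from compound 3 to compound 4 (0.25 log units; that floor lies within the scatter), a fall beyond the scatter.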

Compound 4, dose for half-maximal effect: 34 mg/kg
Beside the measured number, compound 4's estimate is 1.6-fold (0.21 log units) above it, within the range that was stated.
By their numbers in this assay, from the lowest: compounds 1, 4 and 2 (each within the scatter of the next, the first and the last beyond it). At a limit, above all of these: compound 3.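

Compound 3 stands at a limit of the assay, not at a number: the limit of > 100 mg/kg in this assay, at which 1 of the 4 values shown sits.

Even so, in this assay opening the ring can be read as an at least 2.9-fold lower number from compound 3 to compound 4 (0.46 log units; beyond the scatter), and diethylamino has 5 heavy atoms against 6 for piperidin-1-yl, so on this saturated chain carbon bound to a carbonyl carbon, the poorer result goes with the ring rather than with a large gain in atom count. Among the groups without a ring, dimethylamino and diethylamino cannot be told apart, with a 1.3-fold higher number from compound 1 to compound 4 (0.12 log units; within the scatter), and neither can ethyl and diethylamino, with a 1.6-fold lower number from compound 2 to compound 4 (0.21 log units; within the scatter).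

Whether every ring here behaves like piperidin-1-yl stays open, since pyrrolidin-1-yl and morpholin-4-yl do not appear among these compounds. On these data alone, how far the open amine can grow also stays open, for instance to dipropylamino or to a longer chain carrying the amine.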